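This account rests on a few compounds, and the source may have more. Where it says the series, first, only, none or still open, it means among the compounds named here.

Series notes, sulfamate amides.

Two compounds carry numbers in an assay on HEK293 cells for inhibition of Steryl-sulfatase (Homo sapiens), tested at 1 uM; on this read-out lower numbers stand for a weaker effect and higher numbers for a stronger effect at the one concentration tested. Compound 1, `NS(=O)(=O)Oc1ccc2c(c1)CN(C(=O)c1ccc(N(Cc3ccccc3)Cc3ccco3)cc1)CC2`, gives 98.2%, and compound 2, `CCN(Cc1ccccc1)c1ccc(C(=O)N2CCc3ccc(OS(N)(=O)=O)cc3C2)cc1`, gives 83.6%. Going by the values given here, the one step that connects them, methyl in place of furan-2-yl on a saturated chain carbon bound to a nitrogen on an aromatic ring, reads a number 14.6 percentage points lower from compound 1 to compound 2 (beyond the scatter). Compound 2 therefore stands lowest of the two numbers, with compound 1 the nearest and higher.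

Compound 3, `NS(=O)(=O)Oc1ccc2c(c1)CN(C(=O)c1ccc(N(CCCO)Cc3ccccc3)cc1)CC2`, is not yet measured. It differs from compound 2 by hydroxymethyl in place of hydrogen on a saturated chain carbon, two bonds along the chain from a nitrogen on an aromatic ring. Among the compounds with values here, no measured step touches this part of the chain; the only step on record, a number 14.6 percentage points lower from compound 1 to compound 2 (beyond the scatter), concerns the carbon bound to the ring nitrogen and an aromatic ring rather than a chain extension, so it offers a scale but no direction. Both measured compounds sit high in this assay, and the chain in compound 3 is closer in size to that of compound 2 than to the furan-2-yl of compound 1. The expected step is a number 2.6 percentage points lower from compound 2 to compound 3 (within the scatter), small and of uncertain sign.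

Compound 3 is estimated at 81% in this assay, with a range from 62% to 95%.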

Compound 3, a percentage reported as inhibition, at one concentration (the size of the read-out at that concentration, not a potency): 64.3%
Compound 3: middle estimate off by 16.7 percentage points, on the high side; the range from low to high includes it.
By their numbers in this assay, from the lowest: compound 3; then compound 2; then compound 1.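

In this assay, the chain on the nitrogen on the aromatic ring is now shown to matter further out, and not only at the saturated chain carbon bound to that nitrogen: the change from ethyl to 3-hydroxypropyl gives a number 19.3 percentage points lower from compound 2 to compound 3 (beyond the scatter). Read against the furan-2-yl group, 2-hydroxyethyl in place of furan-2-yl at that carbon gives a number 33.9 percentage points lower from compound 1 to compound 3 (beyond the scatter), a large step where the other two steps in the series are modest. The data shown offer no explanation for either step.

The compounds shown do not separate the effect of the added chain length from that of the terminal hydroxyl, so a plain propyl or a 3-methoxypropyl chain on the same nitrogen would be needed to read against compound 3. Also open, as far as these compounds go, is how a terminal amine or a carboxylic acid at the chain end, or a longer chain such as 4-hydroxybutyl, would read in this assay.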